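Closing the Pentan-3-yl Chain of Compound 2 into a Ring

The compounds below may be only part of what the source reports. "The series", "measured", "known", "first", "only" and "open" are said of these compounds alone.

Compound 2 `CCCC(=O)N1CCC(NS(=O)(=O)c2ccc(NC(=O)C(CC)CC)c3ccccc23)CC1` carries a pentan-3-yl group on the amide carbonyl of the shared core. In an in vitro functional assay on CHO/Galpha16 cells for antagonist activity at C-C chemokine receptor type 8 (Homo sapiens), read by FLIPR (a lower number here means a stronger inhibitor, a higher number a weaker inhibitor), compound 2 gives 639 nM, the highest of the three numbers measured. Its nearest neighbour is compound 3 `CCCC(=O)N1CCC(NS(=O)(=O)c2ccc(NC(=O)c3ccc(C(C)(C)C)cc3)c3ccccc23)CC1`, which in this assay gives 6.9 nM; the furthest is compound 1 `CCCC(=O)N1CCC(NS(=O)(=O)c2ccc(NC(=O)C3CCCCC3)c3ccccc23)CC1`, which in this assay gives 6.1 nM. The measured steps are a 93-fold lower number from compound 2 to compound 3 (1.97 log units; beyond the scatter) and a 100-fold higher number from compound 1 to compound 2 (2.02 log units; beyond the scatter).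

Compound 4 `CCCC(=O)N1CCC(NS(=O)(=O)c2ccc(NC(=O)C3CCCC3)c3ccccc23)CC1` differs from compound 2 in one place: cyclopentyl in place of pentan-3-yl on a carbonyl carbon. Both measured steps away from compound 2 replace the open pentan-3-yl chain by a ring, and both are large, so this change is also expected to give a large step down in this assay. The ring entering here is smaller than the cyclohexyl of compound 1. The drop is therefore expected to stop a little short of reversing a 100-fold higher number from compound 1 to compound 2 (2.02 log units; beyond the scatter). Compound 4 is therefore expected to give 15 nM, within a range of 4 nM to 60 nM. That estimate means an expected 43-fold lower number from compound 2 to compound 4 (1.63 log units; beyond the scatter).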

Compound 4, half-maximal inhibitory concentration: 365 nM
Compound 4: the middle estimate sits 24-fold (1.39 log units) below what was measured; the measured number lies above the stated range.
By their numbers in this assay, from the lowest: compounds 1 and 3 (each within the scatter of the next); then compounds 4 and 2 (each within the scatter of the next).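

In this assay, closing the pentan-3-yl chain into cyclopentyl does not by itself reproduce the large steps seen with the other two rings: the change leaves the two compounds within the scatter (a 1.8-fold lower number from compound 2 to compound 4 (0.24 log units; within the scatter)). Having a ring on this carbonyl carbon is therefore not enough, and compound 4 is the exception to the pattern suggested by compound 1 and compound 3, with large steps separating cyclopentyl from cyclohexyl (a 60-fold higher number from compound 1 to compound 4 (1.78 log units; beyond the scatter)) and from 4-(tert-butyl)phenyl (a 53-fold higher number from compound 3 to compound 4 (1.72 log units; beyond the scatter)). Nothing measured here accounts for this gap between the rings.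

The compounds shown leave open where the change sets in, as a cycloheptyl group or a cyclobutyl group would test. They also leave open whether an unsubstituted phenyl would behave like 4-(tert-butyl)phenyl.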